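The compounds below may be only part of what the source reports. "The series", "measured", "known", "first", "only" and "open" are said of these compounds alone.

Measured so far:
compound 1 `COc1cc2c(cc1OC)C(=O)/C(=C/c1ccc(CN3CCCC3)c(O)c1)CO2` — 16.4%
compound 2 `COc1cc2c(cc1OC)C(=O)/C(=C/c1ccc(CN(C)Cc3ccccc3)c(O)c1)CO2` — 3.4%

In an assay on isolated protein for inhibition of Amine oxidase [flavin-containing] A (Homo sapiens), read by fluorescence, with a stated time of 30 min, tested at 20 uM (a higher number here means more inhibition at the concentration tested (going by the name of the read-out), a lower number less inhibition), compound 1 gives 16.4%, the higher of the two numbers; compound 2 gives 3.4%. Among the compounds with values here, the single step in hand, a number 13 percentage points lower from compound 1 to compound 2 (beyond the scatter), exchanges pyrrolidin-1-yl for benzyl(methyl)amino on the saturated chain carbon bound to an aromatic carbon.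

Compound 3 `CCN(Cc1ccccc1)Cc1ccc(/C=C2\COc3cc(OC)c(OC)cc3C2=O)cc1O` is the next case, differing from compound 1 as follows: benzyl(ethyl)amino in place of pyrrolidin-1-yl on a saturated chain carbon bound to an aromatic carbon. Within the data shown here, the entering benzyl(ethyl)amino group is close kin to the benzyl(methyl)amino group of compound 2, so the step of a number 13 percentage points lower from compound 1 to compound 2 (beyond the scatter) is the only relevant guide and is taken as the template: a modest drop beyond the scatter is expected, a number 11.4 percentage points lower from compound 1 to compound 3 (beyond the scatter). Compound 3 is therefore estimated at 5% in this assay, within -4% to 16%; with one reference step only, the range is kept wide.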

Compound 3, a percentage reported as inhibition, at one concentration (the size of the read-out at that concentration, not a potency): 15%
Compound 3: middle estimate off by 10 percentage points, on the low side; measured number inside the range.
By their numbers in this assay, from the lowest: compound 2; then compounds 3 and 1 (each within the scatter of the next).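

In this assay the amine on the saturated chain carbon bound to an aromatic carbon can carry a benzyl group and still give a number within the scatter of the pyrrolidin-1-yl compound, as the exchange for benzyl(ethyl)amino shows (a number 1.4 percentage points lower from compound 1 to compound 3 (within the scatter)). The low number of compound 2 therefore does not follow from the benzyl group alone; the two benzyl amines are separated by one small change, methyl in place of hydrogen on a saturated chain carbon bound to an amine nitrogen (a number 11.6 percentage points higher from compound 2 to compound 3 (beyond the scatter)). No measurement in hand says why the methyl and ethyl amines part in this way.

Going by these compounds, whether a propyl chain on the same nitrogen holds the number or shifts it remains open, as does how a morpholine ring compares with pyrrolidin-1-yl. Each number comes from a single concentration, so none of these compounds has a potency yet.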